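The source may report more compounds than this note shows. Statements on the series, on what has been measured and on what is new or still open speak of the compounds shown alone.

In a functional assay on KYSE-450 cells (Homo sapiens) for inhibition, read by MTT assay, with a stated time of 48 h (a lower number here means a stronger inhibitor, a higher number a weaker inhibitor), compound 3 `COc1ccc(CN(C(=O)CN=[N+]=[N-])c2cc(OC)c(OC)c(OC)c2)cc1O` gives 160 nM, the second highest of the three numbers recorded here: compound 1 `CCC/C=C/C(=O)N(Cc1ccc(OC)c(O)c1)c1cc(OC)c(OC)c(OC)c1` gives 57 nM, while compound 2 `C#CC(=O)N(Cc1ccc(OC)c(O)c1)c1cc(OC)c(OC)c(OC)c1` gives 570 nM. Compound 4 `COc1ccc(CN(C(=O)/C=C/CBr)c2cc(OC)c(OC)c(OC)c2)cc1O` differs from compound 3 in one place: 3-bromoprop-1-en-1-yl in place of azidomethyl on a carbonyl carbon. Among the compounds with values here, two measured steps bear on this change. The same carbonyl carbon carried pent-1-en-1-yl in compound 1, and the change to azidomethyl gave a 2.8-fold higher number from compound 1 to compound 3 (0.45 log units; beyond the scatter); the change from ethynyl in compound 2 gave a 3.6-fold lower number from compound 2 to compound 3 (0.55 log units; beyond the scatter). The 3-bromoprop-1-en-1-yl entering compound 4 resembles the pent-1-en-1-yl of compound 1 rather than the azidomethyl of compound 3. Compound 4 is therefore expected to show a modest fall, a 2.0-fold lower number from compound 3 to compound 4 (0.30 log units; within the scatter). Compound 4 is estimated at 80 nM, within 35 nM to 180 nM.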

Compound 4, half-maximal inhibitory concentration: 100 nM
Compound 4: middle estimate off by 1.3-fold (0.10 log units), on the low side; measured number inside the range.
By their numbers in this assay, from the lowest: compounds 1, 4 and 3 (each within the scatter of the next, the first and the last beyond it); then compound 2.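

In this assay, 3-bromoprop-1-en-1-yl in place of azidomethyl on the carbonyl carbon gives a 1.6-fold lower number from compound 3 to compound 4 (0.20 log units; within the scatter) and so stays within the scatter, while the same group in place of ethynyl gives a 5.7-fold lower number from compound 2 to compound 4 (0.76 log units; beyond the scatter) and lies beyond it. Bromo in place of ethyl on the chain gives a 1.8-fold higher number from compound 1 to compound 4 (0.24 log units; within the scatter) and is also within the scatter, so this position tolerates that exchange without a readable change. The compounds shown leave open how an amine or a longer chain in place of the bromo would fare. No measurement given here accounts for these steps.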